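A few compounds are considered here, and "the series" means these few. Any claim that something is new, unique, unknown or untested is made for them only; others in the source may bear on it.

Measured in a functional assay on microsomes from liver (Rattus norvegicus, strain Wistar) for inhibition, with a stated time of 15 min; a lower number here means a stronger inhibitor, a higher number a weaker inhibitor:
- compound 1 `COc1cc(NC(=O)N2N=C(c3cc4ccccc4o3)CC2c2ccc(O)c(OC)c2)ccc1O`: 12000000 nM
- compound 2 `COc1cc(C2CC(c3cc4ccccc4o3)=NN2C(=O)Nc2ccc(Cl)cc2)ccc1O`: 121000000 nM

Of these two, compound 2 has the higher number, 121000000 nM, and is the weaker inhibitor in this assay. Among the measured compounds shown here, its only neighbour is a 10-fold higher number from compound 1 to compound 2 (1.00 log units; beyond the scatter).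

Compound 3 `COc1cc(C2CC(c3cc4ccccc4o3)=NN2C(=O)Nc2ccc(Br)cc2)ccc1O` is not yet measured. It differs from compound 2 as follows: bromo in place of chloro on an aromatic carbon. This places bromo in place of chloro on an aromatic carbon, para to a large group.

For the measured compounds named here, one measured step bears on this, and only loosely. The step to compound 2 puts 4-chlorophenyl in place of 4-hydroxy-3-methoxyphenyl on an amide-type nitrogen, so it exchanges a whole substituted phenyl, not one halogen for another. Going by the values given here, no measured pair shows a halogen exchange, and two compounds give little basis for a direction. The expectation therefore rests on compound 2 at 121000000 nM, with no step beyond the scatter expected. The estimated change is a 1.1-fold lower number from compound 2 to compound 3 (0.04 log units; within the scatter). Compound 3 is expected at 110000000 nM, with an estimated range of 30000000 nM to 350000000 nM.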

Compound 3, half-maximal inhibitory concentration: 115000000 nM
Compound 3: the middle estimate sits 1.0-fold (0.02 log units) below what was measured; the measured number falls inside the stated range.
By their numbers in this assay, from the lowest: compound 1; then compounds 3 and 2 (each within the scatter of the next).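

In this assay, among the compounds shown here, the exchange of 4-chlorophenyl for 4-bromophenyl gives a 1.1-fold lower number from compound 2 to compound 3 (0.02 log units; within the scatter) and so does not separate the two compounds, which gives the first direct reading of a halogen exchange at this place, para to a large group. The comparison with 4-hydroxy-3-methoxyphenyl on the amide-type nitrogen now holds for a second halogen, with a 9.6-fold higher number from compound 1 to compound 3 (0.98 log units; beyond the scatter) alongside a 10-fold higher number from compound 1 to compound 2 (1.00 log units; beyond the scatter) and both steps beyond the scatter, so compound 1 stands apart from each halogen-bearing compound. No measured evidence bears on the reason for either result.

From the compounds shown here alone, whether this place tolerates other groups remains open, as only chloro and bromo are compared directly here, and fluoro, iodo, methoxy, an amine or a carboxylic acid could read differently. It is also open whether the hydroxy or the methoxy of 4-hydroxy-3-methoxyphenyl carries the larger part of the step, since the compounds shown replace that whole phenyl group at once.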